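The compounds below may be only part of what the source reports. "The series", "measured", "known", "first", "only" and "open" are said of these compounds alone.

Values in a functional assay on A549 cells (Homo sapiens) for inhibition, read by colorimetric assay and MTT assay, with a stated time of 72 h; on this read-out higher numbers stand for weaker inhibition and lower numbers for stronger inhibition

- compound 1 `C/C1=C\CC[C@@]2(C)O[C@@H]2[C@H]2OC(=O)[C@@H](CN3CCCC3)[C@@H]2C[C@H]1O` gives 10000 nM
- compound 2 `C/C1=C\CC[C@@]2(C)O[C@@H]2[C@H]2OC(=O)[C@@H](CN3CCN(C)CC3)[C@@H]2C[C@H]1O` gives 30000 nM
- compound 3 `C/C1=C\CC[C@@]2(C)O[C@@H]2[C@H]2OC(=O)[C@@H](CN3CCCC3)[C@@H]2C[C@@H]1O` gives 9000 nM

Compound 3, at 9000 nM, sits at the low end of the three numbers, level within the scatter with compound 1: a 1.1-fold lower number from compound 1 to compound 3 (0.05 log units; within the scatter). That pair differs only in drawn configuration (the fact that compounds 1 and 3 differ only in the configuration as drawn). Compound 2 reads higher, at 30000 nM.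

Compound 4 `C/C1=C\CC[C@@]2(C)O[C@@H]2[C@H]2OC(=O)[C@@H](CN3CCN(C)CC3)[C@@H]2C[C@@H]1O` carries 4-methylpiperazin-1-yl in place of pyrrolidin-1-yl on a saturated chain carbon bound to a saturated ring carbon. The same exchange has been measured once, on the other configuration, and it went beyond the scatter: a 3.0-fold higher number from compound 1 to compound 2 (0.48 log units; beyond the scatter). For the measured compounds named here, this modest step is the only direct guide. Since configuration alone moved nothing beyond the scatter in compound 3 (a 1.1-fold lower number from compound 1 to compound 3 (0.05 log units; within the scatter)), a step of similar size and direction is expected in this assay, towards weaker inhibition. The expected step is a 3.0-fold higher number from compound 3 to compound 4 (0.48 log units; beyond the scatter). Compound 4 is estimated at 27000 nM, with an expected range of 13000 nM to 60000 nM.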

Compound 4, half-maximal inhibitory concentration: 25000 nM
For compound 4 the middle estimate is 1.1-fold (0.03 log units) above the measured one, within the range that was stated.
By their numbers in this assay, from the lowest: compounds 3 and 1 (each within the scatter of the next); then compounds 4 and 2 (each within the scatter of the next).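

In this assay the exchange of pyrrolidin-1-yl for 4-methylpiperazin-1-yl on a saturated chain carbon bound to a saturated ring carbon can now be read on both drawn configurations, with a 2.8-fold higher number from compound 3 to compound 4 (0.44 log units; beyond the scatter) as the second reading, and the two steps agree: the same change on two cores in this assay, a 3.0-fold higher number (0.48 log units; beyond the scatter) from compound 1 to compound 2 and a 2.8-fold higher number (0.44 log units; beyond the scatter) from compound 3 to compound 4, 1.1-fold (0.03 log units) apart, within the scatter of two such steps.

Changing the drawn configuration at a saturated ring carbon also stays within the scatter with 4-methylpiperazin-1-yl in place (a 1.2-fold lower number from compound 2 to compound 4 (0.08 log units; within the scatter)), so this result no longer rests on the pyrrolidin-1-yl pair alone: the fact that compounds 2 and 4 differ only in the configuration as drawn.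

Open, on these data alone, is whether other groups in this place, such as morpholin-4-yl, dimethylamino or a carboxylic acid, would move the number in this assay below that of compound 3 at 9000 nM. With only two amines shown, the two steps do not establish a trend across amines.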